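The compounds below may be only part of what the source reports. "The series", "measured", "known", "first", "only" and "open" are said of these compounds alone.

For the measured compounds named here, in a physicochemical assay for lipophilicity, measured as octanol-water partition, at pH 7.4 (a lower number here means a more polar compound, a higher number a more lipophilic compound), compound 2 `Cc1ccc2[nH]c(C(=O)N[C@H]3CN(S(=O)(=O)c4ccccc4)CC[C@@H]3C(=O)NCCN(C)C)cc2c1` gives 1.9, the higher of the two numbers so far. Compound 1 `Cc1ccc2[nH]c(C(=O)N[C@H]3CN(S(=O)(=O)C4CCOCC4)C[C@@H]3C(=O)NCCN(C)C)cc2c1` gives 1, which is lower by more than the scatter. Compound 3 `Cc1ccc2[nH]c(C(=O)N[C@H]3CN(S(=O)(=O)c4ccccc4)CC[C@H]3C(=O)NCCN(C)C)cc2c1` differs from compound 2 by the two compounds have the same atoms and bonds and differ only in configuration as drawn: 1 of 2 stereo elements differ; a stereocentre at a saturated ring carbon is drawn S in compound 2 and R in compound 3: a stereocentre at a saturated ring carbon is drawn S in compound 2 and R in compound 3. Going by the values given here, no measured pair isolates a change of configuration, so the data give no direct size for such a step. No step beyond the scatter is expected in this assay, in either direction. This expectation starts from compound 2 at 1.9, whose atoms and bonds compound 3 shares. The estimated step of no change at the digits printed from compound 2 to compound 3 (within the scatter) therefore stays within the scatter. For compound 3 the expected value is 1.9, with an estimated range from 1.5 to 2.3.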

Compound 3, distribution coefficient: 1.9
Compound 3: the middle estimate sits on the measured number at the digits printed; the range from low to high includes it.
By their numbers in this assay, from the lowest: compound 1; then compounds 2 and 3 (each within the scatter of the next).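

In this assay, inverting the stereocentre at the saturated ring carbon, drawn S in one compound and R in the other, gives no change at the digits printed from compound 2 to compound 3 (within the scatter). Among the compounds shown, this is the only pair that isolates a single change, so it gives a direct size for a change of configuration at this position, which the earlier compounds could not provide. The result can be read as one of configuration alone because nothing else separates the pair: the fact that compounds 2 and 3 differ only in the configuration as drawn.

On these data alone, the second stereocentre is drawn the same in this pair, so the effect of inverting it, alone or with the first, remains open. As far as these compounds go, it also remains open whether the two configurations would still read alike with a carboxylic acid in place of the dimethylaminoethyl chain.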